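Sulfur-chain variants all sit at the cytotoxicity limit

The source may hold more compounds than are shown below. What is called first, only, known or untested is meant among the compounds shown, and "the series" means these compounds.

Measured so far, in an ADME assay on A-431 cells (Homo sapiens) for cytotoxicity, with a stated time of 48 h; a lower number here means a stronger inhibitor, a higher number a weaker inhibitor:
Compound 1, `CSc1nnc(-c2cc([N+](=O)[O-])cc([N+](=O)[O-])c2)n1Cc1ccccc1`, gives only a limit of the assay: > 30000 nM.
Compound 2, `CCCSc1nnc(-c2cc([N+](=O)[O-])cc([N+](=O)[O-])c2)n1Cc1ccccc1`, likewise reaches only a limit: > 30000 nM.
Compound 3, `CCCCCCCCSc1nnc(-c2cc([N+](=O)[O-])cc([N+](=O)[O-])c2)n1Cc1ccccc1`, also stops at a limit: > 30000 nM.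

All three compounds share one core and differ only in the chain on the sulfur. None of them gave a number in this assay; every value is a limit, as shown by the limit of > 30000 nM in this assay, at which 3 of the 3 values shown sit. The three steps between them therefore cannot be sized: a step that the two limits leave unreadable from compound 1 to compound 2, a step that the two limits leave unreadable from compound 1 to compound 3 and a step that the two limits leave unreadable from compound 2 to compound 3. Compound 3 thus stands where the other two stand, at the limit, with no position among them that can be read.

Compound 4, `O=[N+]([O-])c1cc(-c2nnc(SCc3ccc(Br)cc3)n2Cc2ccccc2)cc([N+](=O)[O-])c1`, carries the change (4-bromophenyl in place of heptyl on a saturated chain carbon bound to a sulfur). As far as these compounds go, the three measured steps bear on it only in that a methyl, a propyl and an octyl chain on the sulfur all left the value at the limit; how a 4-bromobenzyl chain behaves is untested, and the step size cannot be drawn from them. With no readable movement in the series, the expected step is a number no higher from compound 3 to compound 4 (the limit leaves the size open). Compound 4 is therefore expected to give about 30000 nM, within 10000 nM to 100000 nM, most likely again as a limit rather than a number.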

Compound 4, half-maximal inhibitory concentration: > 30000 nM
Compound 4 gave a limit, no number; the forecaster's own chance of this, stated with the estimate: 75%; the middle value lies on the limit itself.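

In this assay compound 4 also gives only a limit of > 30000 nM and its steps from compound 1, compound 2 and compound 3 cannot be read, as all four compounds stop at the same limit: the limit of > 30000 nM in this assay, at which 4 of the 4 values shown sit.

The compounds shown leave open whether any of these chains on the sulfur changes the cytotoxicity value at all, as none of them has a number.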